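Second Hydroxy Group on the Chain and Lipophilicity

This account rests on a few compounds, and the source may have more. Where it says the series, first, only, none or still open, it means among the compounds named here.

Compound 1, `Cc1cccc(Cl)c1OCC(O)CO`, gives 1.97 in a physicochemical assay for lipophilicity, measured as octanol-water partition; a lower number here means a more polar compound, a higher number a more lipophilic compound.
Compound 2, `Cc1cccc(Cl)c1OCCCO`, gives 2.93 in this assay.
Compound 3, `Cc1cc(OCC(C)O)cc(C)c1Cl`, gives 3.18 in this assay.

Between compound 2 and compound 1 the change is hydroxy in place of hydrogen on a saturated chain carbon bound to two saturated chain carbons, and it brought a number 0.96 log units lower from compound 2 to compound 1 (beyond the scatter). How the core of compound 2 differs from the core of compound 3 is not broken down here. Compound 4, `Cc1cc(OCC(O)CO)cc(C)c1Cl`, is not yet measured. It differs from compound 3 by hydroxy in place of hydrogen on a saturated chain carbon, two bonds along the chain from an oxygen on a saturated carbon, the same kind of change as before, though the place differs: in compound 1 the hydroxy sits on a saturated chain carbon bound to two saturated chain carbons, in compound 4 on a saturated chain carbon, two bonds along the chain from an oxygen on a saturated carbon. A step of a number 0.98 log units lower from compound 3 to compound 4 (beyond the scatter) is expected in this assay, resting on a number 0.96 log units lower from compound 2 to compound 1 (beyond the scatter). Compound 4 is therefore estimated at 2.2, likely between 1.8 and 2.6.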

Compound 4, partition coefficient: 2.42
Compound 4: the middle estimate sits 0.22 log units below what was measured; measured number inside the range.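

In this assay the step is a number 0.76 log units lower from compound 3 to compound 4 (beyond the scatter) on this core and a number 0.96 log units lower from compound 2 to compound 1 (beyond the scatter) on the other, so the hydroxy in place of hydrogen goes with a lower number in both pairs. Among these compounds, that is only two pairs, and the hydroxy does not sit in the same place in each, so the change carried over here, but this does not show that it would carry over to any other core. Nothing shown here explains the fall in the number.

The compounds shown leave open whether another group in the same place on the chain, such as an amine or a carboxylic acid, would shift the number in the same direction. They also leave open whether the step would hold on a longer chain.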